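Swapping a Sugar for Methyl: Expected Cytotoxicity Outcome

The source may hold more compounds than are shown below. What is called first, only, known or untested is meant among the compounds shown, and "the series" means these compounds.

Both measured compounds were tested in a functional assay on HEL cells (Homo sapiens) for cytotoxicity; on this read-out higher numbers stand for lower toxicity in this test and lower numbers for higher toxicity in this test. Compound 1, with structure `CCCCCCCCCCC#Cc1cc2cn(C)c(=O)nc2o1`, carries the longer alkyne chain; in this assay compound 1 reaches only the limit > 150000 nM, which is a boundary of the test rather than a number. Compound 2, with structure `CCCCCCC#Cc1cc2cn([C@@H]3O[C@H](CO)[C@@H](O)[C@H]3O)c(=O)nc2o1`, carries a sugar on the ring nitrogen; in this assay compound 2 likewise gives only a limit, >= 133000 nM, again not a number. Among the measured compounds shown here, compound 2 therefore stands at a limit, and the one other value shown is a limit too. Compound 3, with structure `CCCCCCC#Cc1cc2cn(C)c(=O)nc2o1`, has not yet been measured. The change from compound 2 to compound 3 is methyl in place of 3,4-dihydroxy-5-(hydroxymethyl)oxolan-2-yl on an aromatic nitrogen. For the measured compounds named here, no step between measured compounds is available, so the size of this step cannot be taken from the data. Because the limit of > 150000 nM in this assay, at which 1 of the 2 values shown sits, and the limit of >= 133000 nM in this assay, at which 1 of the 2 values shown sits, place both known values at limits, a step that the limit leaves unreadable from compound 2 to compound 3 in this assay is expected, nothing beyond the scatter. Compound 3 is estimated at 150000 nM in this assay, most likely reported again as a limit, within 50000 nM to 300000 nM.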

Compound 3, minimum cytotoxic concentration: 194000 nM
For compound 3 the middle estimate is 1.3-fold (0.11 log units) below the measured one; measured number inside the range.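

No size can be read for the steps to compound 3 from compound 1 or from compound 2: the values of compound 1 and compound 2 are both limits of the test, not numbers. The compounds shown leave open whether either the sugar or the butyl extension of the chain changes the result in this assay at all.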